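The source may report more compounds than this note shows. Statements on the series, on what has been measured and on what is new or still open speak of the compounds shown alone.

Compounds measured so far:
compound 1 `COc1cccc(OC)c1OCCNCCOc1ccccc1OCc1ccccc1Cl`, 0.562 nM in an assay on CHO cells for displacement of a labelled ligand from Alpha-1B adrenergic receptor (Homo sapiens); on this read-out higher numbers stand for weaker inhibition and lower numbers for stronger inhibition
compound 2 `COc1cccc(OC)c1OCCNCCOc1ccccc1OCc1cccc(C)c1`, 0.251 nM in this assay

Compound 2 stands at the lowest of the two numbers: its nearest neighbour is compound 1, and the step of a 2.2-fold lower number from compound 1 to compound 2 (0.35 log units; beyond the scatter) lies beyond the scatter. Compound 3 `COc1cccc(OC)c1OCCNCCOc1ccccc1OCc1ccc(C)cc1` is not yet measured. It differs from compound 2 in one place: 4-methylphenyl in place of 3-methylphenyl on a saturated chain carbon bound to an oxygen on an aromatic ring. Going by the values given here, the one measured step, a 2.2-fold lower number from compound 1 to compound 2 (0.35 log units; beyond the scatter), also changes the aryl group on the same saturated chain carbon bound to an oxygen on an aromatic ring, but it exchanges a chlorine-bearing ring for a methyl-bearing one rather than moving a methyl group. Among the compounds with values here, no measured pair shows a methyl moved from one ring position to another, so the step expected in this assay from compound 2 to compound 3 is small, within the scatter, with no firm direction; compound 3 is estimated at 0.32 nM, between 0.12 nM and 0.9 nM, a step of a 1.3-fold higher number from compound 2 to compound 3 (0.11 log units; within the scatter).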

Compound 3, inhibition constant: 0.251 nM
Beside the measured number, compound 3's estimate is 1.3-fold (0.11 log units) above it; measured number inside the range.
By their numbers in this assay, from the lowest: compounds 2 and 3 (each within the scatter of the next); then compound 1.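

In this assay, the change to 4-methylphenyl in place of 3-methylphenyl, on a saturated chain carbon bound to an oxygen on an aromatic ring, gives no change at the digits printed from compound 2 to compound 3 (within the scatter), so at this place the read-out does not separate these two methyl placements. The change from 2-chlorophenyl to 4-methylphenyl at the same place gives a 2.2-fold lower number from compound 1 to compound 3 (0.35 log units; beyond the scatter), which matches the step already seen with 3-methylphenyl, and compound 1 stays apart from both methylphenyl compounds. Nothing available explains either result.

Going by these compounds, whether the gap to compound 1 follows the chlorine or its ring placement stays open, and a comparison of 2-methylphenyl with 4-chlorophenyl would bear on that. On these data alone, how a methoxy group or an amine on this ring would read also remains open.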